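The source may report more compounds than this note shows. Statements on the series, on what has been measured and on what is new or still open speak of the compounds shown alone.

Three compounds share one core and differ only in the aromatic group attached to it. Compound 1 `COc1cc(-c2ccnc3cc(-c4ccc(C(C)=O)cc4)nn23)cc(OC)c1OC` gives 4100 nM in a functional assay on A549 cells (Homo sapiens) for inhibition, read by CCK-8 assay, with a stated time of 48 h; on this read-out higher numbers stand for weaker inhibition and lower numbers for stronger inhibition. Compound 2 `COc1ccc(-c2cc3nccc(-c4cc(OC)c(OC)c(OC)c4)n3n2)cc1` gives 376 nM in this assay, and compound 3 `COc1cc(-c2ccnc3cc(-c4ccc5c(ccn5C)c4)nn23)cc(OC)c1OC` gives 15 nM. Compound 3 stands lowest of the three, since a 270-fold lower number from compound 1 to compound 3 (2.44 log units; beyond the scatter) and a 25-fold lower number from compound 2 to compound 3 (1.40 log units; beyond the scatter) are both large, as is an 11-fold lower number from compound 1 to compound 2 (1.04 log units; beyond the scatter). Compound 4 `COc1cc(-c2ccnc3cc(-c4cn(C)c5ccccc45)nn23)cc(OC)c1OC` keeps the same atoms as compound 3, joined differently: 1-methyl-1H-indol-3-yl in place of 1-methyl-1H-indol-5-yl on an aromatic carbon. Within the data shown here, no measured step changes where a group is joined to the core; the measured steps only show that exchanging the whole aromatic group moves the number strongly. The expected step of a 4.0-fold higher number from compound 3 to compound 4 (0.60 log units; beyond the scatter) is a rise, with wide uncertainty. Compound 4 is expected to give 60 nM, in the range 10 nM to 400 nM.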

Compound 4, half-maximal inhibitory concentration: 1340 nM
For compound 4 the middle estimate is 22-fold (1.35 log units) below the measured one; measured number outside the range, above it.
By their numbers in this assay, from the lowest: compound 3; then compound 2; then compound 4; then compound 1.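

Here the indole keeps all its atoms and only its point of attachment changes, yet in this assay that alone gives an 89-fold higher number from compound 3 to compound 4 (1.95 log units; beyond the scatter). So having an indole at this place on the core does not by itself give the low number: the 1-methyl-1H-indol-3-yl group lands close to the phenyl compounds, with a 3.6-fold higher number from compound 2 to compound 4 (0.55 log units; beyond the scatter) and a 3.1-fold lower number from compound 1 to compound 4 (0.49 log units; beyond the scatter). Nothing measured here explains why the joining point matters so much. Also open, as far as these compounds go, is whether a longer chain on the indole nitrogen, or an amine on the 1-methyl-1H-indol-5-yl group, would keep the low number.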